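Swapping Nitro for Chloro on the Fluoro Analogue

The compounds below may be only part of what the source reports. "The series", "measured", "known", "first", "only" and "open" are said of these compounds alone.

Compound 1, `O=[N+]([O-])c1ccc(Oc2ccc(/C=N/NC(=S)Nc3ccc(Br)cc3)cc2)cc1`: 5.68
Compound 2, `S=C(N/N=C/c1ccc(Oc2ccc(Cl)cc2)cc1)Nc1ccc(Br)cc1`: 6.24
Compound 3, `O=[N+]([O-])c1ccc(Oc2ccc(/C=N/NC(=S)Nc3ccc(F)cc3)cc2)cc1`: 4.89

These three values come from a physicochemical assay for lipophilicity, in phosphate buffer, measured as octanol-water partition, with a stated time of 24 h; on this read-out lower numbers stand for lower lipophilicity and higher numbers for higher lipophilicity. Compound 1 and compound 2 differ in one place, (chloro in place of nitro on an aromatic carbon), and this change made the step of a number 0.56 log units higher from compound 1 to compound 2 (beyond the scatter). Compound 1 and compound 3 differ elsewhere, (fluoro in place of bromo on an aromatic carbon), and that change made the step of a number 0.79 log units lower from compound 1 to compound 3 (beyond the scatter), leaving compound 3 with the lowest of the three numbers.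

Compound 4, `Fc1ccc(NC(=S)N/N=C/c2ccc(Oc3ccc(Cl)cc3)cc2)cc1`, has not yet been measured. It differs from compound 3 by chloro in place of nitro on an aromatic carbon, which is the same change that turned compound 1 into compound 2, at a place described in the same words. Of the two occurrences of this change among the four compounds, only one has a measured result. The expected step in this assay from compound 3 to compound 4 is a number 0.56 log units higher from compound 3 to compound 4 (beyond the scatter), resting on the earlier step of a number 0.56 log units higher from compound 1 to compound 2 (beyond the scatter). Compound 4 is therefore estimated at 5.45 in this assay, expected to lie between 5 and 5.9.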

Compound 4, partition coefficient: 5.78
Beside the measured number, compound 4's estimate is 0.33 log units below it; the range from low to high includes it.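

In this assay chloro in place of nitro on the fluoro analogue gave a number 0.89 log units higher from compound 3 to compound 4 (beyond the scatter) and on the bromo analogue gave a number 0.56 log units higher from compound 1 to compound 2 (beyond the scatter), so the change moved the number the same way on both. Fluoro in place of bromo also went the same way on both, with a number 0.79 log units lower from compound 1 to compound 3 (beyond the scatter) and a number 0.46 log units lower from compound 2 to compound 4 (beyond the scatter). These two matched pairs show agreement in direction only, do not establish a rule for the wider series, and come with no measurement that explains the size of either step.

Going by these compounds, how an amine or a carboxylic acid in place of nitro would compare remains open. So does whether a chloro or iodo group in place of the bromo would follow these steps.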